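This account rests on a few compounds, and the source may have more. Where it says the series, first, only, none or still open, it means among the compounds named here.

In an assay on CHO-K1 cells for displacement of a labelled ligand from adenosine receptor A1 (Homo sapiens), read by scintillation counting, with a stated time of 60 min (on this read-out lower numbers stand for stronger inhibition and higher numbers for weaker inhibition), compound 1 `Nc1nc(N/N=C/c2cccc(OCc3ccccc3)c2)nc2c1ncn2[C@@H]1O[C@H](CO)[C@@H](O)[C@H]1O` gives 13 nM. Compound 2 `CCOc1cc(/C=N/Nc2nc(N)c3ncn([C@@H]4O[C@H](CO)[C@@H](O)[C@H]4O)c3n2)ccc1O` stands highest of the two numbers recorded in this assay, giving 6940 nM; its nearest neighbour, compound 1, lies far below it, beyond the scatter. Compound 3 `Nc1nc(N/N=C/c2ccc(C(F)(F)F)cc2C(F)(F)F)nc2c1ncn2[C@@H]1O[C@H](CO)[C@@H](O)[C@H]1O` in this assay gives > 10000 nM, which is a limit of the assay rather than a number, as set out in the limit of > 10000 nM in this assay, at which 1 of the 3 values shown sits. Compound 4 `CCCCc1nc(/C=N/Nc2nc(N)c3ncn([C@@H]4O[C@H](CO)[C@@H](O)[C@H]4O)c3n2)c(Cl)[nH]1` has not yet been measured in this assay; it differs from compound 2 as follows: 2-butyl-5-chloro-1H-imidazol-4-yl in place of 3-ethoxy-4-hydroxyphenyl on a carbon with a double bond to nitrogen. Among the measured compounds shown here, no measured pair differs in one place, so the size of this step is uncertain. For compound 4 the expected step is a 1.2-fold higher number from compound 2 to compound 4 (0.06 log units; within the scatter), which should stay within the scatter. Compound 4 is estimated to give 8000 nM in this assay, with a range from 2000 nM to 30000 nM.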

Compound 4, inhibition constant: 12 nM
The estimate for compound 4 lay 670-fold (2.82 log units) above the measured number, and the stated range ends above it.
By their numbers in this assay, from the lowest: compounds 4 and 1 (each within the scatter of the next); then compound 2. At a limit, above all of these: compound 3.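

In this assay, the change on the carbon with a double bond to nitrogen gives a 580-fold lower number from compound 2 to compound 4 (2.76 log units; beyond the scatter), which shows that the group at this place can move the number greatly. An aromatic ring of carbon only is therefore not required here for a low number. Nothing shown accounts for the size of this step.

Which part of the entering group carries the step stays open, since the ring, the butyl chain and the chlorine all arrive together. On these data alone, whether a propyl chain, or bromine in place of chlorine, would keep the low number is also open.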